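The source may hold more compounds than are shown below. What is called first, only, known or untested is meant among the compounds shown, and "the series" means these compounds.

Measured so far in an ADME assay on T29 cells (Homo sapiens) for cytotoxicity, read by sulforhodamine B assay, with a stated time of 3 days; a lower number here means a stronger inhibitor, a higher number a weaker inhibitor:
- Compound 1 `O=Cc1cn(CCCOc2ccc(Cl)cc2)c2ccccc12`: > 31600 nM
- Compound 2 `CC(O)c1cn(Cc2ccc(Cl)cc2)c2ccccc12`: > 31500 nM

Both entries are limits of the assay, not numbers. Compound 2 therefore has no numerical position in this assay. Its only entry is the limit > 31500 nM. Compound 1 also has only a limit, > 31600 nM. Within the data shown here, the two measured compounds differ in more than one place, so the series offers no measured step to use as a guide.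

Compound 3 `COC(=O)CNCc1cn(Cc2ccc(Cl)cc2)c2ccccc12` carries (((methoxycarbonyl)methyl)amino)methyl in place of 1-hydroxyethyl on an aromatic carbon of the shared core ((((methoxycarbonyl)methyl)amino)methyl in place of 1-hydroxyethyl on an aromatic carbon). Among the measured compounds shown here, the expectation rests on compound 2, whose limit > 31500 nM is the only anchor for this change. A modest shift towards stronger inhibition is expected, and a result that again reaches the limit of this assay would fit equally well. The expected step, an at least 1.2-fold lower number from compound 2 to compound 3 (0.10 log units; that floor lies within the scatter), is therefore small and uncertain. The estimate for compound 3 is 25000 nM, with an expected range of 6000 nM to 32000 nM.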

Compound 3, half-maximal inhibitory concentration: 31600 nM
Compound 3: the middle estimate sits 1.3-fold (0.10 log units) below what was measured, within the range that was stated.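

In this assay compound 2 has only a limit, > 31500 nM, not a number. The step from compound 2 to compound 3 therefore cannot be read. The compounds shown leave open whether any change on this aromatic carbon of the shared core gives clearly stronger inhibition in this assay.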